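Chain growth on a shared core: working notes

The source may hold more compounds than are shown below. What is called first, only, known or untested is meant among the compounds shown, and "the series" means these compounds.

Three compounds have been measured in a functional assay, with a stated time of 16 h; on this read-out higher numbers stand for weaker inhibition and lower numbers for stronger inhibition:

compound 1, `CC(C)=NNc1nc(-c2cccc([N+](=O)[O-])c2)cs1`: 1070000 nM
compound 2, `CCC/C(C)=N\Nc1nc(-c2cccc([N+](=O)[O-])c2)cs1`: 1040000 nM
compound 3, `CCC/C(CC)=N\Nc1nc(-c2cccc([N+](=O)[O-])c2)cs1`: 1040000 nM

Compound 2 differs from compound 1 by ethyl in place of hydrogen on a saturated chain carbon bound to a carbon with a double bond to nitrogen, and the step is a 1.0-fold lower number from compound 1 to compound 2 (0.01 log units; within the scatter). Compound 3 carries one more carbon than compound 2, the step being no change at the digits printed from compound 2 to compound 3 (within the scatter). Set against compound 1, compound 3 shows (a group of 7 heavy atoms (6 carbon, 1 nitrogen; no ring) in place of a group of 4 heavy atoms (3 carbon, 1 nitrogen; no ring), on a nitrogen on an aromatic ring), which gives a 1.0-fold lower number from compound 1 to compound 3 (0.01 log units; within the scatter). All three numbers sit within the usual scatter of one another, so none of the three can be set apart from the others, and nothing about chain length on this carbon has so far moved the read-out.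

Compound 4, `CCCCC/C(CC)=N\Nc1nc(-c2cccc([N+](=O)[O-])c2)cs1`, remains to be measured. From compound 3 it differs by ethyl in place of hydrogen on a saturated chain carbon, three bonds along the chain from a carbon with a double bond to nitrogen. Among the compounds with values here, this is the same kind of change as the one from compound 1 to compound 2, an ethyl entering in place of a hydrogen, but not the same change: there the carbon was bound to a carbon with a double bond to nitrogen, here it lies three bonds along the chain from such a carbon.

The step from compound 3 to compound 4 is expected to be no change at the digits printed from compound 3 to compound 4 (within the scatter), because a 1.0-fold lower number from compound 1 to compound 2 (0.01 log units; within the scatter) and no change at the digits printed from compound 2 to compound 3 (within the scatter) both stayed within the scatter as the earlier chain extensions. Compound 4 is therefore estimated at 1040000 nM, with a likely range from 500000 nM to 2200000 nM.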

Compound 4, half-maximal inhibitory concentration: 1050000 nM
Beside the measured number, compound 4's estimate is 1.0-fold (0.00 log units) below it; low and high end bracket the measured number.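

In this assay the entry of ethyl in place of hydrogen gives a 1.0-fold higher number from compound 3 to compound 4 (0.00 log units; within the scatter) at its new place, and set beside the earlier ethyl step it shows no difference that can be read: the same change on two cores in this assay, a 1.0-fold lower number (0.01 log units; within the scatter) from compound 1 to compound 2 and a 1.0-fold higher number (0.00 log units; within the scatter) from compound 3 to compound 4, 1.0-fold (0.02 log units) apart, within the scatter of two such steps

Within these compounds, then, the change carries from the core of compound 1 to the core of compound 3 with the same outcome, even though the ethyl stands on a saturated chain carbon bound to a carbon with a double bond to nitrogen in one case and three bonds along the chain from such a carbon in the other. This does not show that the step would be the same on any other core, and with both steps inside the scatter, the comparison cannot tell a change that transfers an effect from a change that has no effect to transfer.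

On these data alone, whether an amine or a carboxylic acid on the chain, or a chain longer than that of compound 4, would move the read-out at all remains open. Also open, as far as these compounds go, is whether the ethyl step would hold on a core whose number in this assay lies far from those of these four compounds.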